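Swapping One Five-Membered Ring on a Nitrofuran Chalcone

This account rests on a few compounds, and the source may have more. Where it says the series, first, only, none or still open, it means among the compounds named here.

Measured so far:
compound 1 `O=C(/C=C/c1ccc([N+](=O)[O-])o1)c1ccc(-n2ccnc2)cc1`: 22200 nM
compound 2 `CC(C)(C)c1ccc(C(=O)/C=C/c2ccc([N+](=O)[O-])s2)cc1`: 8400 nM

Both compounds were tested in an ADME assay on THP-1 cells (Homo sapiens) for cytotoxicity, read by resazurin assay, with a stated time of 72 h; a lower number here means that less compound is tolerated, a higher number that more compound is tolerated. Compound 1 gives the higher of the two numbers, and the gap down to compound 2 lies beyond the usual scatter. Compound 3 `O=C(/C=C/c1ccc([N+](=O)[O-])o1)c1ccc(N2CCCC2)cc1` differs from compound 1 by pyrrolidin-1-yl in place of 1H-imidazol-1-yl on an aromatic carbon. Going by the values given here, no measured pair shows this change, so nothing about its effect is known from the data; a step within the scatter, in no particular direction, is the expectation. Compound 3 is therefore estimated at 18000 nM, with a range from 7000 nM to 45000 nM. The expected step is a 1.2-fold lower number from compound 1 to compound 3 (0.09 log units; within the scatter).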

Compound 3, half-maximal cytotoxic concentration: > 50000 nM
Compound 3 was reported as a limit; the forecaster's own chance of this, stated with the estimate: 10%; middle value at least 2.7-fold (0.44 log units) away from the limit.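

Putting pyrrolidin-1-yl in place of 1H-imidazol-1-yl on this aromatic carbon gives an at least 2.2-fold higher number from compound 1 to compound 3 (0.35 log units; beyond the scatter) in this assay, so the group at this position does change the reading on the core of compound 1. For compound 3 the reading > 50000 nM is a limit and not a number. The step therefore gives only a minimum size for the change: the limit of > 50000 nM in this assay, at which 1 of the 3 values shown sits.

On these data alone, how far compound 3 truly lies from compound 1 stays open. So does whether a morpholine ring or an open-chain diethylamine at this position would read as high.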